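Swapping the Phenyl Amide for a Diethylaminopropyl Chain

This account rests on a few compounds, and the source may have more. Where it says the series, first, only, none or still open, it means among the compounds named here.

The three measured compounds, each tested in an assay on isolated protein for inhibition of glutathione S-transferase Mu 2 (Homo sapiens), with a stated time of 10 min; on this read-out lower numbers stand for stronger inhibition and higher numbers for weaker inhibition:
compound 1 `O=C(CCC(=O)OCCCCCCSc1ccc([N+](=O)[O-])c2nonc12)Nc1ccccc1` gives 700 nM
compound 2 `O=C(CCC(=O)OCCCCCCSc1ccc([N+](=O)[O-])c2nonc12)Nc1cccc(Cl)c1` gives 1100 nM
compound 3 `COc1ccc(NC(=O)CCC(=O)OCCCCCCSc2ccc([N+](=O)[O-])c3nonc23)cc1` gives 130 nM

All three share the same core and differ only in the group on the amide nitrogen. Compound 1 carries a plain phenyl there and sits second highest of the three numbers: it is within the scatter of compound 2 (a 1.6-fold higher number from compound 1 to compound 2 (0.20 log units; within the scatter)) and clearly separated from compound 3 (a 5.4-fold lower number from compound 1 to compound 3 (0.73 log units; beyond the scatter)). Compound 2 and compound 3 are also apart (an 8.5-fold lower number from compound 2 to compound 3 (0.93 log units; beyond the scatter)).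

Compound 4 `CCN(CC)CCCNC(=O)CCC(=O)OCCCCCCSc1ccc([N+](=O)[O-])c2nonc12` departs from compound 1 in a different way: 3-(diethylamino)propyl in place of phenyl on an amide-type nitrogen. The measured steps all keep the aromatic ring and only decorate it, so none of them directly tests removing it in favour of a chain. They do show that the amide-nitrogen group matters to this assay, since changing it moved the number by a modest amount in one case. Among the compounds with values here, with no closer precedent, the expectation for compound 4 is a somewhat higher number than compound 1, with wide uncertainty, expressed as a 2.9-fold higher number from compound 1 to compound 4 (0.46 log units; beyond the scatter). The estimated value for compound 4 is 2000 nM, expected to lie between 500 nM and 8000 nM.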

Compound 4, half-maximal inhibitory concentration: 440 nM
Compound 4: the middle estimate sits 4.5-fold (0.66 log units) above what was measured; measured number below the stated range.
By their numbers in this assay, from the lowest: compound 3; then compounds 4, 1 and 2 (each within the scatter of the next, the first and the last beyond it).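

In this assay, this position on the amide-type nitrogen does not depend on keeping an aromatic ring: exchanging phenyl for the ring-free 3-(diethylamino)propyl chain gives (a 1.6-fold lower number from compound 1 to compound 4 (0.20 log units; within the scatter)), so the two groups cannot be told apart here. The chain still does not reach the level of the 4-methoxyphenyl group (a 3.4-fold higher number from compound 3 to compound 4 (0.53 log units; beyond the scatter)), yet it stands clear of the 3-chlorophenyl group (a 2.5-fold lower number from compound 2 to compound 4 (0.40 log units; beyond the scatter)), which places this very different group within the range set by the decorated rings. No measurement available here accounts for why a chain can take the place of a ring at this position.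

The compounds shown leave open whether the amine nitrogen of the chain contributes at all, a question that a plain hexyl chain with no nitrogen on the same amide would help to answer. They also leave open how much the chain length matters, which a shorter 2-(diethylamino)ethyl chain or a longer 4-(diethylamino)butyl chain would test, along with whether a ring amine such as morpholine behaves like the open diethylamino group.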